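Series notes: hydroxypentyloxy to methylbutenyloxy at compound 4

The source may hold more compounds than are shown below. What is called first, only, known or untested is meant among the compounds shown, and "the series" means these compounds.

Within the data shown here, compound 3 `COC[C@H]1CN(c2ccc(OCCCC(C)O)cc2)C(=O)O1` gives the highest reading in a physicochemical assay for lipophilicity (on this read-out higher numbers stand for higher lipophilicity and lower numbers for lower lipophilicity), among the three measured members, at 2.27. Its nearest neighbour is compound 2 `COC[C@H]1CN(c2ccc(CCO)cc2)C(=O)O1`, which in this assay gives 1.13; the furthest is compound 1 `COC[C@H]1CN(c2ccc(OCCO)cc2)C(=O)O1`, which in this assay gives 0.77. The measured steps are a number 0.36 log units higher from compound 1 to compound 2 (beyond the scatter), a number 1.14 log units higher from compound 2 to compound 3 (beyond the scatter) and a number 1.50 log units higher from compound 1 to compound 3 (beyond the scatter).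

Compound 4 `C=C(C)CCOc1ccc(N2C[C@H](COC)OC2=O)cc1` differs from compound 3 as follows: 1-methylethenyl in place of 2-hydroxypropyl on a saturated chain carbon, two bonds along the chain from an oxygen on an aromatic ring. Among the measured compounds shown here, no measured step removes a hydroxy group; the closest precedent is the loss of an oxygen in a number 0.36 log units higher from compound 1 to compound 2 (beyond the scatter), while the chain growth in a number 1.50 log units higher from compound 1 to compound 3 (beyond the scatter) and a number 1.14 log units higher from compound 2 to compound 3 (beyond the scatter) shows how strongly added carbon moves this read-out. The group entering has one fewer heavy atom than the group leaving, yet it carries no hydrogen-bond donor or acceptor, so a rise beyond the scatter is expected, estimated at a number 1.03 log units higher from compound 3 to compound 4 (beyond the scatter). For compound 4 the expected value in this assay is 3.3, within 2.8 to 3.8.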

Compound 4, partition coefficient: 3.03
Compound 4: middle estimate off by 0.27 log units, on the high side; the range from low to high includes it.
By their numbers in this assay, from the lowest: compound 1; then compound 2; then compound 3; then compound 4.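

In this assay, among these compounds, the exchange of 2-hydroxypropyl for 1-methylethenyl at this chain carbon gives a number 0.76 log units higher from compound 3 to compound 4 (beyond the scatter) and is the first step in which the entering group carries no hydrogen-bond donor or acceptor. Against the two shorter side chains the readings are a number 1.90 log units higher from compound 2 to compound 4 (beyond the scatter) and a number 2.26 log units higher from compound 1 to compound 4 (beyond the scatter) and place the new member beyond the scatter above all three earlier members, so the highest reading now belongs to the (3-methylbut-3-en-1-yl)oxy side chain. No independent data on this result are available to explain the rise at this position.

The step removes the hydroxy group and introduces the double bond together, and the two contributions cannot be separated here. As far as these compounds go, whether a saturated 3-methylbutyl chain, an amine or a carboxylic acid at this place would follow the same direction remains open.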